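Benzyloxy extension of an inactive bis-chalcone

The source may hold more compounds than are shown below. What is called first, only, known or untested is meant among the compounds shown, and "the series" means these compounds.

Measured compounds:
compound 1 `Cc1cc(O)c(C(=O)/C=C/c2ccc(Cl)cc2)c(-c2ccccc2)c1C(=O)/C=C/c1ccc(Cl)cc1` — 10000 nM
compound 2 `COc1ccc(/C=C/C(=O)c2c(C)cc(O)c(C(=O)/C=C/c3ccc(OC)c(OC)c3)c2-c2ccccc2)cc1OC` — "not active" (no number reported)
compound 3 `Cc1cc(O)c(C(=O)/C=C/c2ccccc2)c(-c2ccccc2)c1C(=O)/C=C/c1ccccc1` — 10000 nM

In a functional assay on MCF7 cells (Homo sapiens) for cytotoxicity, read by MTT assay, with a stated time of 24 h (a higher number here means a weaker inhibitor, a lower number a stronger inhibitor), compound 1 gives 10000 nM and compound 3 gives 10000 nM; these two values lie within the scatter of each other. Compound 2 stands apart: in this assay it was recorded as "not active" (no number reported), with no number reported, so its position among the measured compounds cannot be fixed.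

Compound 4 `COc1ccc(/C=C/C(=O)c2c(C)cc(O)c(C(=O)/C=C/c3ccc(OC)c(OC)c3)c2-c2ccc(OCc3ccccc3)cc2)cc1OC` differs from compound 2 by benzyloxy in place of hydrogen on an aromatic carbon. For the measured compounds named here, no measured step of this kind exists, and the only reference point is a compound without a number. No step beyond the scatter is expected in this assay in either direction; compound 4 is expected to remain weak, likely near the values of compound 1 and compound 3 or again without a number. Compound 4 is estimated at 10000 nM, range 3000 nM to 50000 nM.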

Compound 4, half-maximal inhibitory concentration: 30000 nM
Compound 4: the middle estimate sits 3.0-fold (0.48 log units) below what was measured; the measured number falls inside the stated range.
By their numbers in this assay, from the lowest: compounds 1 and 3 (each within the scatter of the next); then compound 4.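

For the compounds shown here, with compound 2 recorded without a number in this assay, no step to compound 4 can be read. No available data bear on this result. As far as these compounds go, the effect of benzyloxy in place of hydrogen on this read-out remains open.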